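Alkyl branching on the aromatic ring: a test compound

A few compounds are considered here, and "the series" means these few. Any claim that something is new, unique, unknown or untested is made for them only; others in the source may bear on it.

Compound 1 `CCCCCCCC/C=C\CCCCCCCCNC(=O)Nc1c(CC)cccc1C(C)C` and compound 2 `CCCCCCCC/C=C\CCCCCCCCNC(=O)Nc1c(C(C)C)cccc1C(C)C` share a core and differ in one place: methyl in place of hydrogen on a saturated chain carbon bound to an aromatic carbon and a saturated chain carbon. In an assay on microsomes from intestinal mucosa for inhibition of acyl-CoA:cholesterol acyltransferase (Oryctolagus cuniculus) (on this read-out higher numbers stand for weaker inhibition and lower numbers for stronger inhibition), compound 1 gives 37 nM and compound 2 gives 28 nM, so the change made a 1.3-fold lower number from compound 1 to compound 2 (0.12 log units; within the scatter). Compound 3 `CCCCCCCCCCNC(=O)Nc1c(C)cccc1C(C)C` carries a different core; the difference between the two cores is not broken down here. In this assay compound 3 gives 210 nM, the highest of the three numbers, beyond the scatter from both compound 1 and compound 2.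

Compound 4 `CCCCCCCCCCNC(=O)Nc1c(C)cccc1C(C)(C)C` is the not yet measured partner of compound 3, and the change from compound 3 to compound 4 is methyl in place of hydrogen on a saturated chain carbon bound to an aromatic carbon and two saturated chain carbons. Within the data shown here, it is the same kind of change as the one from compound 1 to compound 2, but not the same: in compound 1 the carbon that takes the methyl is bound to an aromatic carbon and a saturated chain carbon, in compound 3 it is bound to an aromatic carbon and two saturated chain carbons, so that the change reads isopropyl to tert-butyl rather than ethyl to isopropyl.

Among the measured compounds shown here, the only precedent for this kind of change is the step from compound 1 to compound 2, which stayed within the scatter, so for compound 4 a step of about a 1.2-fold lower number from compound 3 to compound 4 (0.09 log units; within the scatter) is expected, because of a 1.3-fold lower number from compound 1 to compound 2 (0.12 log units; within the scatter). On that basis compound 4 is estimated at 170 nM in this assay, expected between 80 nM and 360 nM.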

Compound 4, half-maximal inhibitory concentration: 200 nM
Beside the measured number, compound 4's estimate is 1.2-fold (0.07 log units) below it, within the range that was stated.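

In this assay the added methyl gives a 1.1-fold lower number from compound 3 to compound 4 (0.02 log units; within the scatter), so on this core the change from isopropyl to tert-butyl moves the read-out no further than repeat measurements would. Set beside the earlier step, the change from ethyl to isopropyl on the core of compound 1, the two results do not differ: the same change on two cores in this assay, a 1.3-fold lower number (0.12 log units; within the scatter) from compound 1 to compound 2 and a 1.1-fold lower number (0.02 log units; within the scatter) from compound 3 to compound 4, 1.3-fold (0.10 log units) apart, within the scatter of two such steps This shows only that in these two pairs the added methyl left the number unmoved on both cores; it does not show that the step is independent of the core in general, as the two steps start from different groups and neither is large enough to reveal how a core might alter a step of real size.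

The compounds shown leave open what separates the core of compound 3 from the core of compound 1, as these differ in more than one place, so the higher number of compound 3 cannot be assigned to any single part of the structure. Also open, from the compounds shown here alone, is whether a group of a different kind in place of the tert-butyl, such as an amine or a carboxylic acid, would move the number on either core.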